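Notes on the aryl substituent in the thioether series

The source may report more compounds than this note shows. Statements on the series, on what has been measured and on what is new or still open speak of the compounds shown alone.

Two compounds of the series have numbers. Compound 1 `O=[N+]([O-])c1cccc(SCc2ncnc3c2ncn3[C@@H]2O[C@H](CO)[C@@H](O)[C@H]2O)c1` gives 4.79 nM in an assay on isolated protein for binding affinity to Equilibrative nucleoside transporter 1 (Homo sapiens); on this read-out lower numbers stand for stronger inhibition and higher numbers for weaker inhibition. Among the measured compounds shown here, compound 2 `COc1ccc(SCc2ncnc3c2ncn3[C@@H]2O[C@H](CO)[C@@H](O)[C@H]2O)cc1` gives 617 nM and so stands at the higher of the two numbers; the only measured step, a 130-fold higher number from compound 1 to compound 2 (2.11 log units; beyond the scatter), is the exchange of the aryl substituent on the sulfur. Compound 3 `CC(C)(C)c1ccc(SCc2ncnc3c2ncn3[C@@H]2O[C@H](CO)[C@@H](O)[C@H]2O)cc1` is not yet measured. It differs from compound 2 by tert-butyl in place of methoxy on an aromatic carbon. For the measured compounds named here, no measured step covers an exchange of this kind; the step from compound 1 to compound 2 shows only that the group on this ring can move the number a great deal, in either sense, and gives no direction for a tert-butyl. The expectation for compound 3 is therefore a step of a 1.5-fold lower number from compound 2 to compound 3 (0.19 log units; within the scatter) with wide uncertainty. Compound 3 is estimated at 400 nM, within 80 nM to 2000 nM.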

Compound 3, half-maximal inhibitory concentration: 331000 nM
Compound 3: middle estimate off by 830-fold (2.92 log units), on the low side; measured number outside the range, above it.
By their numbers in this assay, from the lowest: compound 1; then compound 2; then compound 3.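

In this assay, a substituent on this ring can do far more than the step between the first two compounds showed: a 540-fold higher number from compound 2 to compound 3 (2.73 log units; beyond the scatter) for tert-butyl in place of methoxy, with the two groups on the same aromatic carbon. Across the aryl exchange, 4-(tert-butyl)phenyl in place of 3-nitrophenyl gives a 69000-fold higher number from compound 1 to compound 3 (4.84 log units; beyond the scatter), so the three compounds span a very wide range with the rest of the structure unchanged. The exchange both adds heavy atoms and removes the hydrogen-bond acceptor of the methoxy, and nothing available explains the loss or separates these two changes.

Open, as far as these compounds go, is whether a smaller alkyl group such as methyl or isopropyl at this place gives a number nearer compound 2 or compound 3. Also open, from the compounds shown here alone, is how an amine or a carboxylic acid here would read, and how a nitro group would read on the carbon that carries tert-butyl in compound 3.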